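Cyano for ethynyl on a saturated ring carbon: cytotoxicity

The compounds below may be only part of what the source reports. "The series", "measured", "known", "first", "only" and "open" are said of these compounds alone.

Of the compounds shown here, three have been tested in an ADME assay on MT4 cells (Homo sapiens) for cytotoxicity, read by luminescence and CellTiter-Glo, with a stated time of 48 h; a higher number here means that more compound is tolerated, a lower number that less compound is tolerated. Compound 1 `C#CC1(CO)CC(n2cnc3c(N)nc(F)nc32)CC1O` carries an ethynyl group on a saturated ring carbon. In this assay compound 1 gives > 42000 nM, which is a limit of the assay and not a number. Compound 2 `N#CC1(CO)CC(n2cnc3c(N)nc(F)nc32)CC1O` differs from compound 1 by cyano in place of ethynyl on a saturated ring carbon. In this assay compound 2 gives > 42000 nM, again a limit. The step that the two limits leave unreadable from compound 1 to compound 2 therefore cannot be read. Compound 3 `C#CC1(CO)CC(n2cnc3c(=O)[nH]c(N)nc32)CC1O` rests on a different core; how the two cores differ is not broken down here. In this assay compound 3 gives > 42000 nM, once more a limit. All three measured values sit at the limit of > 42000 nM in this assay, at which 3 of the 3 values shown sit.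

Compound 4 `N#CC1(CO)CC(n2cnc3c(=O)[nH]c(N)nc32)CC1O` is not yet measured in this assay; it differs from compound 3 by cyano in place of ethynyl on a saturated ring carbon, the same change as the one made between the first two compounds. Because the limit of > 42000 nM in this assay, at which 3 of the 3 values shown sit, holds for every measured compound shown, compound 4 is expected to sit at that limit as well, so the expected step is a step that the limit leaves unreadable from compound 3 to compound 4. For compound 4 the estimate is 60000 nM, expected to lie between 30000 nM and 150000 nM, and most probably reported only as a limit.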

Compound 4, half-maximal cytotoxic concentration: > 42000 nM
Compound 4 ended at the assay's limit; the forecaster's own chance of this, stated with the estimate: 85%; the middle value is on the limit's open side.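

Compound 3 and compound 4 both end at a limit in this assay and not at a number, so no size can be read for the change from ethynyl to cyano: the limit of > 42000 nM in this assay, at which 4 of the 4 values shown sit. The compounds shown leave open at what concentration any of them becomes toxic to these cells, and whether the two groups differ there.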